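Methyl in Place of Trifluoromethyl: Expecting Compound 4

The source may report more compounds than this note shows. Statements on the series, on what has been measured and on what is new or still open speak of the compounds shown alone.

Of the compounds shown here, three have so far been tested in an ADME assay on HEK293 cells (Homo sapiens) for cytotoxicity, read by resazurin assay, with a stated time of 48 h; a higher number here means that more compound is tolerated, a lower number that less compound is tolerated. Compound 1 `COc1ccc(S(=O)(=O)Nc2ccc(-c3nc4ccccc4o3)cc2)cc1` returns only a limit of this assay, reported as > 100000 nM. Compound 2 `O=S(=O)(Nc1ccc(-c2nc3ccccc3o2)cc1)c1ccccc1C(F)(F)F` likewise returns only a limit, > 100000 nM. Compound 3 `O=S(=O)(Nc1ccc2oc(-c3ccccc3)nc2c1)c1ccccc1C(F)(F)F` returns a number, 80000 nM. Going by the values given here, compound 2 therefore stands at the limit of > 100000 nM in this assay, at which 2 of the 3 values shown sit, a limit rather than a measured value, and no step between measured compounds that differ in a single place is available to set beside it. Compound 4 `Cc1ccccc1S(=O)(=O)Nc1ccc(-c2nc3ccccc3o2)cc1` differs from compound 2 by methyl in place of trifluoromethyl on an aromatic carbon. The step of a number no higher from compound 2 to compound 4 (the limit leaves the size open) is expected to be none beyond the usual scatter. Compound 4 is accordingly estimated at 100000 nM, within 50000 nM to 300000 nM, with a further limit the likeliest outcome.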

Compound 4, half-maximal cytotoxic concentration: > 100000 nM
Compound 4 ended at the assay's limit (the forecaster's own chance of this, stated with the estimate: 75%); the middle value sits exactly at the limit.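

In this assay compound 4, like compound 1 and compound 2, sits at a limit, so neither new step can be read. The compounds shown leave open how much compound these three actually tolerate and whether they differ.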